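Chloro on the Benzyl Ring of Compound 3

The source may hold more compounds than are shown below. What is called first, only, known or untested is meant among the compounds shown, and "the series" means these compounds.

Among the measured compounds shown here, compound 3 `N#CCCN1N=C(c2ccc(OCc3ccccc3)cc2)OCC1=O` shows the highest of the three numbers so far, although its value lies within the scatter of that of compound 2. In an assay for inhibition of Amine oxidase [flavin-containing] B (Rattus norvegicus) (a higher number here means a weaker inhibitor, a lower number a stronger inhibitor), compound 3 gives 18 nM. Compound 2 `Cc1ccc(COc2ccc(-c3nn(CCC#N)c(=O)o3)cc2)cc1` gives 15 nM, and compound 1 `N#CCCn1nc(-c2ccc(OCc3ccccc3)cc2)oc1=O` gives 2.2 nM, clearly below both. Compound 4 `N#CCCN1N=C(c2ccc(OCc3cccc(Cl)c3)cc2)OCC1=O` differs from compound 3 by chloro in place of hydrogen on an aromatic carbon. For the measured compounds named here, the only measured step touching this ring is a 6.8-fold higher number from compound 1 to compound 2 (0.83 log units; beyond the scatter), made on a different core with a different group, so its bearing is loose. A modest rise in the number, or none beyond the scatter, is therefore expected. Compound 4 is estimated at 35 nM in this assay, with a range from 8 nM to 150 nM. The expected step is a 1.9-fold higher number from compound 3 to compound 4 (0.29 log units; within the scatter).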

Compound 4, half-maximal inhibitory concentration: 13 nM
Compound 4: middle estimate off by 2.7-fold (0.43 log units), on the high side, and the stated range covers the measured number.
By their numbers in this assay, from the lowest: compound 1; then compounds 4, 2 and 3 (each within the scatter of the next).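

In this assay, chloro in place of hydrogen, turning benzyl into 3-chlorobenzyl, gives a 1.4-fold lower number from compound 3 to compound 4 (0.14 log units; within the scatter), so at this place on this core the added chlorine leaves the number indistinguishable from that of the parent. Among the compounds shown here, the only earlier step on this ring, a 6.8-fold higher number from compound 1 to compound 2 (0.83 log units; beyond the scatter), was a methyl step on a different core and lay beyond the scatter. No available evidence bears on this result. The compounds shown leave open whether a bromo, methoxy or trifluoromethyl group would be tolerated at this place, and whether chloro would behave alike on the core of compound 1.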